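Chloro Added to an Inactive Benzyl Compound

The source may hold more compounds than are shown below. What is called first, only, known or untested is meant among the compounds shown, and "the series" means these compounds.

Measured so far:
- compound 1, `O=c1nc2ccc(Br)cn2cc1Cc1ccccc1`: > 1000000 nM (a limit of the assay, not a number)
- compound 2, `O=C1N=C2C=CC=CN2CC1C(O)c1cccs1`: 166000 nM

Both were tested in a functional assay on MCF7 cells (Homo sapiens) for cytotoxicity, read by MTT assay, with a stated time of 24 h; a higher number here means a weaker inhibitor, a lower number a stronger inhibitor. Compound 1 stands at the limit of this assay rather than at a number, as the limit of > 1000000 nM in this assay, at which 1 of the 2 values shown sits, records, so its potency cannot be placed. Compound 2 gives a measured value in this assay. Within the data shown here, no two measured compounds differ in only one place, so no measured step is available to lean on.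

Compound 3, `O=c1nc2ccc(Br)cn2cc1Cc1ccc(Cl)cc1`, differs from compound 1 by chloro in place of hydrogen on an aromatic carbon. With compound 1 sitting at the limit, the step of an at least 1.2-fold lower number from compound 1 to compound 3 (0.09 log units; that floor lies within the scatter) is expected to be no larger than the scatter, with no firm direction. Compound 3 is therefore estimated to give about 800000 nM in this assay, within 200000 nM to 3000000 nM, and may well return only a limit again.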

Compound 3, half-maximal inhibitory concentration: > 1000000 nM
Compound 3: no number, only a limit; the forecaster's own chance of this, stated with the estimate: 60%; middle value at least 1.2-fold (0.09 log units) away from the limit.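

Compound 1 and compound 3 both stop at a limit of the assay rather than at a number, so no step from one to the other can be read: the limit of > 1000000 nM in this assay, at which 2 of the 3 values shown sit.

The compounds shown leave open whether chloro in place of hydrogen on an aromatic carbon changes potency at all in this assay.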